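The compounds below may be only part of what the source reports. "The series", "measured", "known", "first", "only" and "open" are said of these compounds alone.

Compound 3 `O=C(/C=C/c1ccccc1)OC1(C(=O)Nc2ccc([N+](=O)[O-])cc2)CCCCC1` stands second highest of the three numbers in a functional assay on NFS-60 cells (Mus musculus) for inhibition, read by MTT assay, with a stated time of 72 h; a lower number here means a stronger inhibitor, a higher number a weaker inhibitor: compound 3 gives 50.5 nM, close to compound 1 `Cc1ccc(C(=O)OC2(C(=O)Nc3ccc([N+](=O)[O-])cc3)CCCCC2)cc1`, which gives 45.4 nM, and well apart from compound 2 `O=C(OC1(C(=O)Nc2ccc([N+](=O)[O-])cc2)CCCCC1)c1ccc(Br)cc1`, which gives 236 nM. The step of a 1.1-fold higher number from compound 1 to compound 3 (0.05 log units; within the scatter) lies within the scatter, whereas a 4.7-fold lower number from compound 2 to compound 3 (0.67 log units; beyond the scatter) lies beyond it, as does a 5.2-fold higher number from compound 1 to compound 2 (0.72 log units; beyond the scatter).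

The step to compound 4 `O=COC1(C(=O)Nc2ccc([N+](=O)[O-])cc2)CCCCC1` consists of hydrogen in place of 2-phenylethenyl on a carbonyl carbon. Going by the values given here, none of the measured steps repeats this change: each of them exchanges one aryl or styryl group for another on the carbonyl carbon or on its aromatic ring, and the ester's aromatic part is kept in every measured compound. They show only that varying this part moves the number modestly, as in a 4.7-fold lower number from compound 2 to compound 3 (0.67 log units; beyond the scatter) and a 5.2-fold higher number from compound 1 to compound 2 (0.72 log units; beyond the scatter), or leaves it unchanged, as in a 1.1-fold higher number from compound 1 to compound 3 (0.05 log units; within the scatter). Removing the whole 2-phenylethenyl group goes further than any of these exchanges, so the expected direction is toward a higher number in this assay, with wide uncertainty around its size. The estimated step is a 7.9-fold higher number from compound 3 to compound 4 (0.90 log units; beyond the scatter). Compound 4 is therefore expected to give about 400 nM, within a range from 80 nM to 3000 nM.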

Compound 4, half-maximal inhibitory concentration: 33.8 nM
Estimate against measurement, compound 4: 12-fold (1.07 log units) above, outside the stated range (below it).
By their numbers in this assay, from the lowest: compounds 4, 1 and 3 (each within the scatter of the next); then compound 2.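

In this assay, the whole 2-phenylethenyl group, with its six-membered aromatic ring and its double bond outside aromatic rings, gives way to hydrogen on the carbonyl carbon with no change beyond the scatter (a 1.5-fold lower number from compound 3 to compound 4 (0.17 log units; within the scatter)), and the same holds for the loss of 4-methylphenyl (a 1.3-fold lower number from compound 1 to compound 4 (0.13 log units; within the scatter)). The earlier exchanges had kept an aromatic part throughout, whereas these steps show that, among the compounds shown, such a part is not needed at this position to keep the number at the level of compound 1 and compound 3, and only compound 2 stands apart (a 7.0-fold lower number from compound 2 to compound 4 (0.84 log units; beyond the scatter)). The information available offers no explanation for this pattern.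

The compounds shown leave open how a methyl group, a longer alkyl chain, an amine or a carboxylic acid on this carbonyl carbon would read in this assay, so it remains unknown whether hydrogen is matched by other small groups. They also leave open whether the gap of compound 2 belongs to bromo alone, as chloro or fluoro in its place could show, and what happens when the nitro group on the shared core gives way to an amine.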